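The compounds below may be only part of what the source reports. "The series", "measured", "known", "first", "only" and "open" are said of these compounds alone.

Working notes on the series. In an ADME assay on microsomes from liver (Homo sapiens) for metabolic stability (a lower number here means slower removal, a higher number faster removal of the compound), compound 1 `CCOc1cc([C@](O)(CCN(C)C)[C@@H](c2cc3cc(Br)ccc3nc2OC)c2ccnc(OC)c2OC)cc(OC)n1` gives 3.8 uL/min, and compound 2 `COc1cc([C@](O)(CCN(C)C)[C@@H](c2cc3cc(Br)ccc3nc2OC)c2ccnc(OC)c2OC)cc(OC(F)F)n1` gives 2.1 uL/min. Between them lies a 1.8-fold lower number from compound 1 to compound 2 (0.26 log units; within the scatter), so the two numbers are not separated. Compound 2 therefore holds the lower of the two numbers without standing apart from compound 1. Compound 3 `COc1nc2ccc(Br)cc2cc1[C@@H](c1ccnc(OC)c1OC)[C@@](O)(CCN(C)C)c1cc(SC)nc(SC)c1` is not yet measured in this assay; it differs from compound 2 by a group of 10 heavy atoms (7 carbon, 1 nitrogen, 2 sulfur; one six-membered aromatic ring with 1 hetero atom) in place of a group of 12 heavy atoms (7 carbon, 1 nitrogen, 2 oxygen, 2 fluorine; one six-membered aromatic ring with 1 hetero atom), on a saturated chain carbon bound to an oxygen on a saturated carbon and two saturated chain carbons. Going by the values given here, no measured step covers an exchange of this kind: the only step known, a 1.8-fold lower number from compound 1 to compound 2 (0.26 log units; within the scatter), concerns a different exchange and stays within the scatter, so it offers little guidance on direction or size. With two compounds close to each other, the expectation for compound 3 rests mainly on the value of compound 2, 2.1 uL/min, with a broad range around it. Compound 3 is expected to give 5 uL/min, between 1.5 uL/min and 20 uL/min. The expected step is a 2.4-fold higher number from compound 2 to compound 3 (0.38 log units; beyond the scatter), which may or may not exceed the scatter.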

Compound 3, intrinsic clearance in a liver preparation (reported as CLH), per the amount of preparation that the assay uses: 8.8 uL/min
For compound 3 the middle estimate is 1.8-fold (0.25 log units) below the measured one; measured number inside the range.
By their numbers in this assay, from the lowest: compounds 2 and 1 (each within the scatter of the next); then compound 3.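

In this assay, going by these compounds alone, the group of 10 heavy atoms with 2 sulfur, on a saturated chain carbon bound to an oxygen on a saturated carbon and two saturated chain carbons, gives the first steps beyond the scatter: a 4.2-fold higher number from compound 2 to compound 3 (0.62 log units; beyond the scatter) and a 2.3-fold higher number from compound 1 to compound 3 (0.36 log units; beyond the scatter). The exchange on this group therefore separates compound 3 from both oxygen-bearing compounds, whereas compound 1 and compound 2 remain within the scatter of each other. Nothing measured here indicates the origin of the higher number.

Whether the higher number needs both sulfur atoms remains open, since the compounds shown offer no ring carrying sulfur on one substituent and oxygen on the other. Also open, from the compounds shown here alone, is how this series would read with an amine or a nitrile on that aromatic ring.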